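The source may hold more compounds than are shown below. What is called first, only, known or untested is meant among the compounds shown, and "the series" means these compounds.

In an assay on HEK293 cells for activation of Kir3.1/Kir3.2 (Homo sapiens), read by thallium flux (a higher number here means a larger maximal response, a lower number a smaller maximal response), three compounds built on one shared core have been measured. Compound 1 `Cc1cc(NC(=O)Cn2nnc(-c3ccccc3)n2)n(C2CCCCC2)n1` gives 92%. Compound 2 `Cc1cc(NC(=O)Cn2nnc(-c3cccnc3)n2)n(C2CCCCC2)n1` gives 96%. Compound 3 `Cc1cccc(-c2nnn(CC(=O)Nc3cc(C)nn3C3CCCCC3)n2)c1` gives 93%, the second highest of the three numbers, yet all three lie within the usual scatter of one another, so no real separation can be claimed. The step of a number 1 percentage points higher from compound 1 to compound 3 (within the scatter) and the step of a number 3 percentage points lower from compound 2 to compound 3 (within the scatter) both stay within that scatter, so swapping groups on this outer aromatic ring has so far left the maximal response essentially unmoved. Compound 4 `COc1cccc(-c2nnn(CC(=O)Nc3cc(C)nn3C3CCCCC3)n2)c1` differs from compound 3 by methoxy in place of methyl on an aromatic carbon. Among the measured compounds shown here, no measured step replaces a methyl by a methoxy, so this particular exchange is untested, but every change made so far on this ring has stayed within the scatter, and the same is expected here. The expected step of no change at the digits printed from compound 3 to compound 4 (within the scatter) is therefore none beyond the scatter. Compound 4 is estimated at 93%, with a range from 83% to 103%.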

Compound 4, largest response reached (Emax), in percent of the reference or control that the assay uses: 76%
For compound 4 the middle estimate is 17 percentage points above the measured one; measured number outside the range, below it.
By their numbers in this assay, from the lowest: compound 4; then compounds 1, 3 and 2 (each within the scatter of the next).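

In this assay, among the compounds shown here, the outer ring proved less tolerant of change than the earlier compounds suggested: 3-methoxyphenyl in place of 3-methylphenyl gives a number 17 percentage points lower from compound 3 to compound 4 (beyond the scatter), the first step to pass the scatter. The other two comparisons agree, with a number 20 percentage points lower from compound 2 to compound 4 (beyond the scatter) and a number 16 percentage points lower from compound 1 to compound 4 (beyond the scatter), whereas methyl in place of hydrogen stayed within the scatter, so the response at this position depends on which group is present, not simply on the ring carrying a group there. Nothing available explains why methoxy behaves differently from methyl.

Going by these compounds, it remains open whether this drop is particular to methoxy or is shared by groups such as ethyl, hydroxy or an amine at the same place. Also open, on these data alone, is whether methoxy on another carbon of this ring would give a similar drop.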